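Dropping the bromo from the anilino compounds

The source may hold more compounds than are shown below. What is called first, only, known or untested is meant among the compounds shown, and "the series" means these compounds.

In a functional assay on MGC-803 cells (Homo sapiens) for inhibition, read by sulforhodamine B assay (a lower number here means a stronger inhibitor, a higher number a weaker inhibitor), compound 1 `Cc1ccc(NC2=CC(=O)c3c(nc4n3[C@H]3OC[C@@H](O)[C@H]3OC4)C2=O)cc1` gives 1550 nM and compound 3 `O=C1C=C(Nc2ccc(Br)cc2)C(=O)c2c1nc1n2[C@H]2OC[C@@H](O)[C@H]2OC1` gives 1010 nM, two values within the scatter of each other. Compound 2 `O=C1C(N2CCCCC2)=CC(=O)c2c1nc1n2[C@H]2OC[C@@H](O)[C@H]2OC1` reads > 4000 nM, which is a limit of the assay and not a number.

Compound 4 `O=C1C=C(Nc2ccccc2)C(=O)c2c1nc1n2[C@H]2OC[C@@H](O)[C@H]2OC1` is the next case: hydrogen in place of bromo on an aromatic carbon. In words, hydrogen in place of bromo on an aromatic carbon, para to a large group.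

For the measured compounds named here, the only measured step, an at least 2.5-fold higher number from compound 1 to compound 2 (0.41 log units; beyond the scatter), replaces the whole substituent and not just the group lost here, so it sets no size for this change. The closer guide is the agreement between compound 1 at 1550 nM and compound 3 at 1010 nM. No step beyond the scatter is therefore expected in this assay, and no direction can be called with confidence. The estimated change, a 1.3-fold higher number from compound 3 to compound 4 (0.11 log units; within the scatter), is expected to stay within the scatter. For compound 4 the expected value is 1300 nM, with an estimated range from 600 nM to 3000 nM.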

Compound 4, half-maximal inhibitory concentration: 1730 nM
The estimate for compound 4 lay 1.3-fold (0.12 log units) below the measured number; measured number inside the range.
By their numbers in this assay, from the lowest: compounds 3, 1 and 4 (each within the scatter of the next). At a limit, above all of these: compound 2.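

Taking off the bromo gives the first direct reading of this place in this assay (a 1.7-fold higher number from compound 3 to compound 4 (0.23 log units; within the scatter)), so a bromo on this aromatic carbon, para to a large group, is not required for a value in this range. With the phenyl of compound 4 alongside the 4-bromophenyl of compound 3 and the 4-methylphenyl of compound 1, hydrogen, bromo and methyl at this place are not told apart in this assay. Nothing given here offers a cause for this small step.

On these data alone, compound 2 reads > 4000 nM, which is a limit of the assay and not a number, so its distance from the anilino compounds stays unknown. Still open, as far as these compounds go, is whether a carboxylic acid or an amine at this place on the phenyl ring would shift the number beyond the scatter.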